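Shrinking the Amide Ring: Cyclobutyl to Cyclopropyl

The compounds below may be only part of what the source reports. "The series", "measured", "known", "first", "only" and "open" are said of these compounds alone.

Compound 1, `NC(=O)/C=C1\CCc2ccc(Br)cc21`: 21%
Compound 2, `COc1ccc2c(c1)CC/C2=C\C(N)=O`: 25%
Compound 3, `O=C(/C=C1\CCc2ccc(F)cc21)NC1CCC1`: 0%

All three were run in a functional assay on the whole organism with Rattus norvegicus as the target, at a dose of 20 mg/kg by the oral route; a lower number here means less inhibition, a higher number more inhibition at the dose given (going by the name of the read-out). Compound 3 stands lowest of the three numbers; compound 1 lies above it by a gap beyond the scatter, and compound 2 lies further above, also beyond the scatter. Compound 4, `O=C(/C=C1\CCc2ccc(F)cc21)NC1CC1`, differs from compound 3 in one place: cyclopropyl in place of cyclobutyl on an amide-type nitrogen. For the measured compounds named here, no measured pair shows a step of this kind, so the expectation for compound 4 in this assay rests only on the reading of compound 3, 0%, which leaves little room for a fall. The step from cyclobutyl to cyclopropyl is expected to be small, not beyond the scatter: a number 6 percentage points higher from compound 3 to compound 4 (within the scatter). Compound 4 is therefore estimated to give 6%, within a range from 0% to 20%.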

Compound 4, a percentage reported as inhibition, in the whole organism at one dose (the size of the read-out at that dose, not a potency): 7%
For compound 4 the middle estimate is 1 percentage points below the measured one, within the range that was stated.
By their numbers in this assay, from the lowest: compounds 3 and 4 (each within the scatter of the next); then compounds 1 and 2 (each within the scatter of the next).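

In this assay, cyclopropyl in place of cyclobutyl on the amide-type nitrogen gives a number 7 percentage points higher from compound 3 to compound 4 (within the scatter) and so stays within the scatter. This single step shows that, on the core of compound 3, this change of ring leaves the read-out without a clear shift. No evidence at hand bears on this result. The compounds shown leave open whether a cyclopentyl ring, a longer chain or a chain ending in an amine on this nitrogen would shift the read-out beyond the scatter.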